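The source may report more compounds than this note shows. Statements on the series, on what has been measured and on what is new or still open speak of the compounds shown alone.

Compound 1 `COC(=O)c1cc(OCC(=O)[C@H](CC(=O)O)NC(=O)[C@@H](NC(=O)COc2cccc3ccccc23)C(C)C)no1` is the reference, and in a functional assay on Jurkat cells (Homo sapiens) for inhibition (on this read-out higher numbers stand for weaker inhibition and lower numbers for stronger inhibition), compound 1 gives 71000 nM. Compound 3 `CC(C)[C@H](NC(=O)COc1cccc2ccccc12)C(=O)N[C@@H](CC(=O)O)C(=O)COc1ccnc(C(F)(F)F)n1` carries the other number shown, giving 37000 nM in this assay, and the two compounds lie within the scatter of each other, the step being a 1.9-fold lower number from compound 1 to compound 3 (0.28 log units; within the scatter). Compound 2 `CC(C)[C@H](NC(=O)COc1cccc2ccccc12)C(=O)N[C@@H](CC(=O)O)C(=O)CSc1nc2ccccc2s1` gives only a limit of this assay, > 200000 nM, as noted in the limit of > 200000 nM in this assay, at which 1 of the 3 values shown sits. Compound 4 `CC(C)[C@H](NC(=O)COc1cccc2ccccc12)C(=O)N[C@@H](CC(=O)O)C(=O)CSc1nccc(C(F)(F)F)n1` differs from compound 1 by (4-(trifluoromethyl)pyrimidin-2-yl)sulfanyl in place of (5-(methoxycarbonyl)-1,2-oxazol-3-yl)oxy on a saturated chain carbon bound to a carbonyl carbon. Going by the values given here, two measured steps bear on this change. Exchanging the (5-(methoxycarbonyl)-1,2-oxazol-3-yl)oxy for a sulfanyl-linked aromatic gave an at least 2.8-fold higher number from compound 1 to compound 2 (0.44 log units; beyond the scatter), while the (2-(trifluoromethyl)pyrimidin-4-yl)oxy gave a 1.9-fold lower number from compound 1 to compound 3 (0.28 log units; within the scatter), and between those two ends stands an at least 5.4-fold lower number from compound 2 to compound 3 (0.73 log units; beyond the scatter). Compound 4 joins the sulfur linkage of compound 2 to a trifluoromethyl-bearing pyrimidine like that of compound 3, so the step is expected to run toward weaker inhibition, a 1.5-fold higher number from compound 1 to compound 4 (0.19 log units; within the scatter), though less far than compound 2 went. Compound 4 is therefore estimated at 110000 nM, within a range from 40000 nM to 300000 nM.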

Compound 4, half-maximal inhibitory concentration: > 200000 nM
Compound 4: only a limit was reported (the forecaster's own chance of this, stated with the estimate: 30%); at least 1.8-fold (0.25 log units) between middle value and limit.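

In this assay, the (4-(trifluoromethyl)pyrimidin-2-yl)sulfanyl group on a saturated chain carbon bound to a carbonyl carbon gives an at least 2.8-fold higher number from compound 1 to compound 4 (0.44 log units; beyond the scatter) and an at least 5.4-fold higher number from compound 3 to compound 4 (0.73 log units; beyond the scatter), so a trifluoromethyl-bearing pyrimidine does not keep the number of compound 3 in this form. Among the four compounds, both sulfanyl-linked compounds reach a limit of the assay, whereas both oxy-linked compounds give numbers: the limit of > 200000 nM in this assay, at which 2 of the 4 values shown sit. The step from compound 2 to compound 4 cannot be read, so the two rings on sulfur cannot be ranked.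

Compound 3 and compound 4 differ in both the linking atom and the pyrimidine attachment, so the compounds shown do not say which of these carries the step. A (4-(trifluoromethyl)pyrimidin-2-yl)oxy group would separate the two.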